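Methoxy for hydrogen on an aryl ketone pyrazole series

The source may hold more compounds than are shown below. What is called first, only, known or untested is meant among the compounds shown, and "the series" means these compounds.

The three measured compounds share a pyrazole linked to an enone. Compound 1 `COc1ccc(-c2cc(/C=C/C(=O)c3ccc(N)cc3)[nH]n2)cc1` carries an aminophenyl ketone; in a functional assay on HCT-116 cells (Homo sapiens) for cytotoxicity, read by sulforhodamine B assay, with a stated time of 48 h, tested at 0.01 uM (a higher number here means a weaker effect of the compound at the concentration tested, a lower number a stronger effect), compound 1 gives 97%. Compound 3 `COc1ccc(-c2cc(/C=C/C(=O)c3ccc(N)cc3)[nH]n2)cc1OC` differs from it by methoxy in place of hydrogen on an aromatic carbon, and in this assay compound 3 gives 96%. The step of a number 1 percentage points lower from compound 1 to compound 3 (within the scatter) is within the scatter. Compound 2 `COc1ccc(C(=O)/C=C/c2cc(-c3cc(OC)c(OC)c(OC)c3)n[nH]2)cc1OC` has a different core; how the two cores differ is not broken down here. In this assay compound 2 gives 99%, and its numbers against compound 1 and compound 3 all sit within the scatter.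

Compound 4 `COc1cc(C(=O)/C=C/c2cc(-c3cc(OC)c(OC)c(OC)c3)n[nH]2)cc(OC)c1OC`, not yet measured, differs from compound 2 by methoxy in place of hydrogen on an aromatic carbon. This is the same kind of change as from compound 1 to compound 3, but here the place is also meta to a methoxy group. Resting on the step of a number 1 percentage points lower from compound 1 to compound 3 (within the scatter), the expected step is a number 1 percentage points lower from compound 2 to compound 4 (within the scatter), within the scatter. Compound 4 is therefore estimated to give 98% in this assay, with a range from 90% to 100%.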

Compound 4, a percentage reported as activity, at one concentration (the size of the read-out at that concentration, not a potency): 97%
For compound 4 the middle estimate is 1 percentage points above the measured one, within the range that was stated.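

In this assay, methoxy in place of hydrogen on an aromatic carbon gives a number 2 percentage points lower from compound 2 to compound 4 (within the scatter). Set beside the earlier case, the change reads alike on the two cores, with no difference between the steps that rises above the scatter: the same change on two cores in this assay, a number 1 percentage points lower (within the scatter) from compound 1 to compound 3 and a number 2 percentage points lower (within the scatter) from compound 2 to compound 4, 1 percentage points apart, within the scatter of two such steps. Going by these compounds alone, this shows only that the change left the read-out within the scatter on both cores at the single concentration tested; it does not show that a real effect of the same size carries from one core to the other, as neither step can be told from repeat variation, and two compounds pairs are too few to stand for the series.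

What the compounds shown leave open is whether a different group in the same place, such as an ethoxy group, a hydroxyl group or a chlorine atom, would also leave the read-out within the scatter. They also leave open how the two pairs would compare at other concentrations, where a step large enough to read might appear.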